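The source may hold more compounds than are shown below. What is called first, only, known or untested is meant among the compounds shown, and "the series" means these compounds.

Measured so far:
- Compound 1 `c1cnc2c(c1)CCC[C@@H]2N(CC1CC1)C[C@H]1Cc2c(cccc2N2CCNCC2)CN1`: 82.1%
- Compound 2 `CN(C[C@H]1Cc2c(cccc2N2CCN(C3COC3)CC2)CN1)[C@H]1CCCc2cccnc21`: 83.1%

Both values come from an ADME assay on microsomes from liver (Homo sapiens) for metabolic stability, read by LC-MS, with a stated time of 10 min; a lower number here means that less of the compound is left, a higher number that more of the compound is left. There, compound 2 stands at 83.1%, level with compound 1 within the usual scatter, so neither can be ranked above the other.

Compound 3 `C[C@@H]1CN(c2cccc3c2C[C@H](CN(C)[C@H]2CCCc4cccnc42)NC3)C[C@H](C)N1` has not yet been measured. It carries 3,5-dimethylpiperazin-1-yl in place of the 4-(oxetan-3-yl)piperazin-1-yl of compound 2, on an aromatic carbon: 3,5-dimethylpiperazin-1-yl in place of 4-(oxetan-3-yl)piperazin-1-yl on an aromatic carbon. For the measured compounds named here, no measured pair isolates this change, so the direct evidence is thin. Compound 1 at 82.1% and compound 2 at 83.1% give only a general level to start from. A small loss is expected, possibly no larger than the scatter, and the estimated change is a number 4.1 percentage points lower from compound 2 to compound 3 (within the scatter). The estimate for compound 3 is 79%, with an expected range from 64% to 92%.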

Compound 3, percent of the compound remaining: 100%
For compound 3 the middle estimate is 21 percentage points below the measured one, and the stated range ends below it.
By their numbers in this assay, from the lowest: compounds 1 and 2 (each within the scatter of the next); then compound 3.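

In this assay, the group on this aromatic carbon proves able to move the read-out: 3,5-dimethylpiperazin-1-yl in place of 4-(oxetan-3-yl)piperazin-1-yl gives a number 16.9 percentage points higher from compound 2 to compound 3 (beyond the scatter). For the compounds shown here, the earlier compounds differed in more than one place and could not show this, so this is the first single change at this position that exceeds the scatter. The change removes the four-membered ring and brings in a hydrogen-bond donor and two defined stereocentres, but no measurement shown explains the step.

From the compounds shown here alone, it remains open whether the two methyl groups or the loss of the oxetane accounts for the step. Also open, going by these compounds, are how a morpholin-4-yl or a 4-methylpiperazin-1-yl group would read on this carbon, and whether the same step would appear with the cyclopropylmethyl amine of compound 1.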